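The source may report more compounds than this note shows. Statements on the series, on what has been measured and on what is new or still open speak of the compounds shown alone.

Of the compounds shown here, three have so far been measured in a functional assay on MIA PaCa-2 cells (Homo sapiens) for inhibition, read by MTT assay, with a stated time of 3 days; on this read-out higher numbers stand for weaker inhibition and lower numbers for stronger inhibition. Compound 1 `CCOC(=O)[C@@H]1CCCN(S(=N)(=O)c2ccc(S(=O)(=O)N(CC)CC)cc2)C1` gives 4700 nM in this assay. Compound 3 `CCOC(=O)[C@@H]1CCCN(S(=O)(=O)c2ccc(S(=O)(=O)N(CC)CC)cc2C)C1` gives 1200 nM in this assay. Compound 2 `CC(C)c1noc(N2CCN(C(=O)[C@@H]3CCCN(S(=O)(=O)c4ccc(S(=O)(=O)C5CCC5)cc4)C3)CC2)n1` gives 20 nM in this assay, the lowest of the three numbers; its gap to compound 3, the nearest, and its gap to compound 1, the furthest, both lie beyond the usual scatter, so compound 2 is the most potent of the three measured compounds. Going by the values given here, compound 1 and compound 3 differ from compound 2 in more than one place at once, so no single step between measured compounds can be isolated from the numbers at hand.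

Compound 4 `CC(C)c1noc(N2CCN(C(=O)[C@@H]3CCCN(S(=O)(=O)c4ccc(S(=O)(=O)NC5CCC5)cc4)C3)CC2)n1` has not yet been measured. It differs from compound 2 in one place: cyclobutylamino in place of cyclobutyl on a sulfonyl sulfur. Among the compounds with values here, no pair of measured compounds isolates this change, so no measured step guides the expectation, and the account rests on the structural change alone. The expectation is that compound 4 stays close to compound 2 in this assay, with an expected step of a 2.0-fold higher number from compound 2 to compound 4 (0.30 log units; within the scatter), that is, a small loss at most and possibly nothing beyond the scatter. Compound 4 is estimated at 40 nM in this assay, with a range from 10 nM to 200 nM.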

Compound 4, half-maximal inhibitory concentration: 200 nM
Compound 4: the middle estimate sits 5.0-fold (0.70 log units) below what was measured; measured number inside the range.
By their numbers in this assay, from the lowest: compound 2; then compound 4; then compound 3; then compound 1.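

Going by these compounds alone, putting cyclobutylamino in place of cyclobutyl on a sulfonyl sulfur whose other neighbour is an aromatic carbon gives a 10-fold higher number from compound 2 to compound 4 (1.00 log units; beyond the scatter) in this assay and is the first single change that can be read in this set, showing that the number at this position responds to a small edit. The four-membered carbon ring stays in both compounds, and the edit brings in a nitrogen and a hydrogen-bond donor at the link to the sulfonyl sulfur, so the link itself, and not only the ring it carries, counts towards the value in this pair. This one pair cannot say which part of the added group goes with the higher number, and nothing available here bears on why the number rises.

Going by these compounds, what remains open is whether the step follows the hydrogen on the new nitrogen, a question that a methyl group on that nitrogen or an ether oxygen in its place would address. Also open, on these data alone, is how this position would respond to a cyclopentyl ring or to an open chain such as isopropylamino in place of the cyclobutyl group.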